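Amine substitution in a propargylamine series: working notes

A few compounds are considered here, and "the series" means these few. Any claim that something is new, unique, unknown or untested is made for them only; others in the source may bear on it.

Measured so far in an assay on isolated protein for inhibition of Amine oxidase [flavin-containing] B (Homo sapiens), read by fluorescence and Amplex Red, with a stated time of 15 min; on this read-out lower numbers stand for stronger inhibition and higher numbers for weaker inhibition:
- compound 1 `C#CCNCc1cn(-c2cc(NC(=S)NCC)ncn2)cn1` gives 5240 nM
- compound 2 `C#CCN(C)Cc1cn(-c2cc(NC(=S)NCC)ncn2)cn1` gives 1430 nM
- compound 3 `C#CCN(CC#C)Cc1cn(-c2cc(NC(=S)NCC)ncn2)cn1` gives > 50000 nM

Of the two numbers shown, compound 1 has the highest; compound 2 is nearest, with a 3.7-fold lower number from compound 1 to compound 2 (0.56 log units; beyond the scatter). For compound 3 the value is a limit of this assay, not a number, as shown by the limit of > 50000 nM in this assay, at which 1 of the 3 values shown sits.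

Compound 4 `C#CCN1CCN(Cc2cn(-c3cc(NC(=S)NCC)ncn3)cn2)CC1` is not yet measured. It differs from compound 1 by 4-propargylpiperazin-1-yl in place of propargylamino on a saturated chain carbon bound to an aromatic carbon.

Within the data shown here, two measured steps bear on this. Substitution on the amine nitrogen with methyl gave a 3.7-fold lower number from compound 1 to compound 2 (0.56 log units; beyond the scatter), so a tertiary amine is tolerated. A second propargyl on the same nitrogen gave an at least 9.5-fold higher number from compound 1 to compound 3 (0.97 log units; beyond the scatter) and, from compound 2, an at least 34-fold higher number from compound 2 to compound 3 (1.54 log units; beyond the scatter). Among the measured compounds shown here, compound 4 keeps a single propargyl and a tertiary nitrogen bound to the saturated chain carbon, but the propargyl now sits on the other ring nitrogen of the 4-propargylpiperazin-1-yl group, a change no measured step covers directly. The expected step is therefore small, in either direction, and the uncertainty is wide.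

Compound 4 is estimated at 8000 nM, between 1500 nM and 50000 nM, meaning an expected 1.5-fold higher number from compound 1 to compound 4 (0.18 log units; within the scatter).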

Compound 4, half-maximal inhibitory concentration: > 50000 nM
Compound 4: a limit, no number; the forecaster's own chance of this, stated with the estimate: 25%; middle value at least 6.2-fold (0.79 log units) from the limit.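

Compound 4 shows that a single propargyl and a tertiary nitrogen bound to the saturated chain carbon are not enough to keep a measurable number at this position: 4-propargylpiperazin-1-yl in place of propargylamino gives an at least 9.5-fold higher number from compound 1 to compound 4 (0.97 log units; beyond the scatter), and in place of methyl(propargyl)amino it gives an at least 34-fold higher number from compound 2 to compound 4 (1.54 log units; beyond the scatter). Among the earlier compounds, only compound 3, with a second propargyl on the amine nitrogen, had reached the limit, but compound 4 carries one propargyl and still ends there, so a second propargyl is not the only change at this position with that outcome: the limit of > 50000 nM in this assay, at which 2 of the 4 values shown sit. Compound 3 and compound 4 both stand at this limit, so the step between them cannot be read.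

The compounds shown leave open whether the loss goes with the ring itself, with the other ring nitrogen, or with the propargyl sitting on that nitrogen and not on the one bound to the saturated chain carbon. On these data alone, how a morpholin-4-yl or a 4-methylpiperazin-1-yl group would read at this place remains unknown, and these are the groups that would separate those readings.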